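Working notes: methoxy in place of methyl

This account rests on a few compounds, and the source may have more. Where it says the series, first, only, none or still open, it means among the compounds named here.

Among the measured compounds shown here, compound 3 `Cc1ccc(N2C(=O)COc3ccc(-c4cccc(NS(=O)(=O)c5ccc(F)cc5)c4)cc32)cc1` is the one member of the series with a measured number: in a functional assay on MCF7 cells (Homo sapiens) for antiproliferative activity, read by MTT assay, with a stated time of 72 h (on this read-out higher numbers stand for weaker inhibition and lower numbers for stronger inhibition), compound 3 gives 32100 nM. Compound 1 `O=C1COc2ccc(-c3cccc(NS(=O)(=O)c4ccc(F)cc4)c3)cc2N1C1CC1` reaches only a limit of the assay, giving > 40000 nM. Compound 2 `O=C1COc2ccc(-c3cccc(NS(=O)(=O)c4ccc(F)cc4)c3)cc2N1c1ccc(F)cc1` likewise reaches only a limit, giving > 40000 nM. the limit of > 40000 nM in this assay, at which 2 of the 3 values shown sit, is the boundary in question. Because of those limits, an at least 1.2-fold lower number from compound 1 to compound 3 (0.09 log units; that floor lies within the scatter) is a floor only, as is an at least 1.2-fold lower number from compound 2 to compound 3 (0.09 log units; that floor lies within the scatter), while a step that the two limits leave unreadable from compound 1 to compound 2 cannot be read at all. Compound 4 `COc1ccc(N2C(=O)COc3ccc(-c4cccc(NS(=O)(=O)c5ccc(F)cc5)c4)cc32)cc1` carries the change (methoxy in place of methyl on an aromatic carbon). For the measured compounds named here, no measured step touches a methoxy group, and the two readable steps arrive at compound 3 from limits, so they say only that compound 3 sits at or beyond where compounds 1 and 2 stop. Nothing here supports a move beyond the scatter in this assay. The step of a 1.1-fold lower number from compound 3 to compound 4 (0.03 log units; within the scatter) is therefore expected to amount to little, with a fair chance of another limit. Compound 4 is estimated at 30000 nM, within 12000 nM to 80000 nM.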

Compound 4, half-maximal inhibitory concentration: 32400 nM
The estimate for compound 4 lay 1.1-fold (0.03 log units) below the measured number; measured number inside the range.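

In this assay, methoxy in place of methyl gives a 1.0-fold higher number from compound 3 to compound 4 (0.00 log units; within the scatter), so this carbon, para to a large group, now has a measured pair, and that pair shows no separation. The steps of an at least 1.2-fold lower number from compound 2 to compound 4 (0.09 log units; that floor lies within the scatter) and an at least 1.2-fold lower number from compound 1 to compound 4 (0.09 log units; that floor lies within the scatter) are floors only and, like the steps reaching compound 3, show no separation beyond the scatter. Room for reading a change at this position stays narrow, set by the boundary of the assay: the limit of > 40000 nM in this assay, at which 2 of the 4 values shown sit.

Still open, going by these compounds, is whether a group of another kind on this carbon, such as an amine or a carboxylic acid, would move the number beyond the scatter. Also open, on these data alone, is whether a change to the sulfonamide part of the shared core, rather than to this aromatic ring, would give a number well away from the limit.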